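The compounds below may be only part of what the source reports. "The series", "measured", "known", "first", "only" and "open" are said of these compounds alone.

Measured so far:
compound 1, `CS(=O)(=O)c1ccc(Cc2nnc3n2N=C(c2ccccc2)CS3)cc1`: 55.5%
compound 2, `Cc1ccc(C2=Nn3c(Cc4ccc(S(C)(=O)=O)cc4)nnc3SC2)cc1`: 38.5%

Within the data shown here, in a functional assay on HT-29 cells (Homo sapiens) for cytotoxicity, read by MTT assay, with a stated time of 48 h, tested at 100 uM (a higher number here means a stronger effect of the compound at the concentration tested, a lower number a weaker effect), compound 2 stands lowest of the two numbers, the only measured step being a number 17 percentage points lower from compound 1 to compound 2 (beyond the scatter), a modest drop for methyl in place of hydrogen on an aromatic carbon. Compound 3, `CS(=O)(=O)c1ccc(Cc2nnc3n2N=C(c2ccc(O)c(C(N)=O)c2)CS3)cc1`, differs from compound 2 by 3-carbamoyl-4-hydroxyphenyl in place of 4-methylphenyl on a carbon with a double bond to nitrogen. Among the measured compounds shown here, no measured step covers this exchange of one aromatic ring substituent pattern for another, so the single step gives little guidance, and a wide range is warranted. Compound 3 is estimated at 50%, between 25% and 75%. The expected step is a number 11.5 percentage points higher from compound 2 to compound 3 (beyond the scatter), a modest rise, though it could also fall within the scatter.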

Compound 3, a percentage reported as activity, at one concentration (the size of the read-out at that concentration, not a potency): 37.1%
Compound 3: the middle estimate sits 12.9 percentage points above what was measured; the range from low to high includes it.
By their numbers in this assay, from the lowest: compounds 3 and 2 (each within the scatter of the next); then compound 1.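

In this assay, the step of a number 1.4 percentage points lower from compound 2 to compound 3 (within the scatter) shows that 3-carbamoyl-4-hydroxyphenyl and 4-methylphenyl cannot be told apart at this carbon, despite their different counts of hydrogen-bond donors and acceptors. The step of a number 18.4 percentage points lower from compound 1 to compound 3 (beyond the scatter) gives a second substituted ring that lies beyond the scatter under plain phenyl, as the methyl step did. Nothing measured here bears on why these two rings read alike. Left open is whether the hydroxyl or the carbamoyl alone gives this result, and whether a ring carrying an amine or a carboxylic acid would read closer to plain phenyl.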